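A few compounds are considered here, and "the series" means these few. Any claim that something is new, unique, unknown or untested is made for them only; others in the source may bear on it.

Measured in a functional assay on OVCAR-5 cells (Homo sapiens) for cytotoxicity, read by sulforhodamine B assay, with a stated time of 48 h; on this read-out higher numbers stand for weaker inhibition of growth and lower numbers for stronger inhibition of growth:
Compound 1 `ClCc1cccc(Cn2cnc3ncnc(Cl)c32)c1` gives 20000 nM
Compound 2 `ClCc1ccccc1Cn1cnc2ncnc(Cl)c21` gives 7240 nM
Compound 3 `ClCc1ccc(Cn2cnc3c(Cl)nc(Cl)nc32)cc1` gives 34700 nM

Compound 2 stands at the lowest of the three numbers. Compound 1 lies higher, and the gap from compound 2 up to compound 1 is beyond the scatter; compound 3 lies higher still, also beyond the scatter. Among the compounds with values here, compound 3 is the only measured member carrying two chloro groups on the shared core and gives the highest number of the set, but it differs from compounds 1 and 2 elsewhere in the molecule as well, so its number cannot be read as the effect of a second chloro alone.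

Compound 4 `ClCc1ccccc1Cn1cnc2nc(Cl)nc(Cl)c21` has not yet been measured. It differs from compound 2 by chloro in place of hydrogen on an aromatic carbon. Within the data shown here, no pair of measured compounds isolates this single change, so the size of the step is open. The expectation is a step toward weaker growth inhibition in this assay, modest in size and possibly not beyond the scatter, resting only on compound 3 with 34700 nM being the dichloro member and the highest number. Compound 4 is estimated at 11000 nM, with a range from 4000 nM to 32000 nM. The step expected from this estimate is a 1.5-fold higher number from compound 2 to compound 4 (0.18 log units; within the scatter).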

Compound 4, concentration for total growth inhibition: 5750 nM
For compound 4 the middle estimate is 1.9-fold (0.28 log units) above the measured one, and the stated range covers the measured number.
By their numbers in this assay, from the lowest: compounds 4 and 2 (each within the scatter of the next); then compounds 1 and 3 (each within the scatter of the next).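

In this assay, within the data shown here, chloro in place of hydrogen on the aromatic carbon between two ring nitrogen atoms gives a 1.3-fold lower number from compound 2 to compound 4 (0.10 log units; within the scatter); this is the first direct reading of this change, and it shows that this position accepts a chloro group without a shift beyond the scatter. The second chloro group on the shared core is thus not tied to a high number by itself: compound 3 gives 34700 nM, whereas compound 4, which also carries two chloro groups on the core, gives 5750 nM. No measurement available here accounts for the size of this step.

Whether this position stays as permissive for other groups is open, since an amine, a methoxy group or a longer chain in place of the chloro could give a very different number. Also open, on these data alone, is whether the same change reads alike when the chloromethyl group sits elsewhere on the benzyl ring, as neither compound 1 nor compound 3 has a partner differing only by this chloro.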